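A few compounds are considered here, and "the series" means these few. Any claim that something is new, unique, unknown or untested is made for them only; others in the source may bear on it.

Measured in a functional assay on PC-3 cells (Homo sapiens), read by MTT assay, with a stated time of 48 h; a higher number here means a weaker inhibitor, a lower number a stronger inhibitor:
- compound 1 `CCn1c(C(=O)NCCCN(C)C)ccc1C(CC)(CC)c1ccc(OCC(=O)C(C)(C)C)c(C)c1` gives 1600 nM
- compound 2 `CCN(CC)CCNC(=O)c1ccc(C(CC)(CC)c2ccc(OCC(O)C(C)(C)C)c(C)c2)n1CC` gives 220 nM
- compound 3 `CCn1c(C(=O)NCCN(C)C)ccc1C(CC)(CC)c1ccc(OCC(O)C(C)(C)C)c(C)c1` gives 1630 nM

Compound 3 stands level with compound 1, within the usual scatter, and well above compound 2 on these numbers. The next compound, compound 4 `CCn1c(C(=O)NCCCN(C)C)ccc1C(CC)(CC)c1ccc(OCC(O)C(C)(C)C)c(C)c1`, keeps everything in compound 3 except the end of the side chain: (dimethylamino)methyl in place of dimethylamino on a saturated chain carbon, two bonds along the chain from an amide-type nitrogen. In other words, (dimethylamino)methyl stands in place of dimethylamino on a saturated chain carbon, two bonds along the chain from an amide-type nitrogen. Among the compounds with values here, only one measured step touches this place, a 7.4-fold higher number from compound 2 to compound 3 (0.87 log units; beyond the scatter), so changes here can move the number by a modest amount. That step altered the amine end, however, and not the chain length, so it gives no direction. Compound 1 already carries the 3-(dimethylamino)propyl group but differs from compound 4 elsewhere, and compound 1 gives 1600 nM. No shift beyond the scatter is therefore expected, and the expected change is a 1.4-fold lower number from compound 3 to compound 4 (0.13 log units; within the scatter). The estimate for compound 4 is 1200 nM, with an expected range of 350 nM to 3000 nM.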

Compound 4, half-maximal inhibitory concentration: 3100 nM
Compound 4: the middle estimate sits 2.6-fold (0.41 log units) below what was measured; measured number above the stated range.
By their numbers in this assay, from the lowest: compound 2; then compounds 1, 3 and 4 (each within the scatter of the next).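

Read in this assay the longer chain gives a 1.9-fold higher number from compound 3 to compound 4 (0.28 log units; within the scatter) when 2-(dimethylamino)ethyl becomes 3-(dimethylamino)propyl, so chain length alone produces no clear shift here. The change from diethylamino on the shorter chain to dimethylamino on the longer one gives a 14-fold higher number from compound 2 to compound 4 (1.15 log units; beyond the scatter) and lies beyond the scatter, as does the step from compound 2 to compound 3, so both compounds that lose diethylamino at this position end up clearly apart from compound 2. Elsewhere in the molecule, 1-hydroxy-2,2-dimethylpropyl in place of (tert-butyl)carbonyl gives a 1.9-fold higher number from compound 1 to compound 4 (0.29 log units; within the scatter) and so shows no clear effect with this side chain.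

Still open, on these data alone, is whether 3-(diethylamino)propyl would match compound 2, and how a ring amine such as piperidine or a longer 4-(dimethylamino)butyl chain would behave at this position. No outside evidence explains these numbers.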